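From 4-methoxybenzyl to 4-chlorobenzyl

The source may hold more compounds than are shown below. What is called first, only, known or untested is meant among the compounds shown, and "the series" means these compounds.

Two compounds have been measured in a physicochemical assay for solubility, with a stated time of 3 days, at pH 7 (a higher number here means a more soluble compound, a lower number a less soluble compound), so far:
Compound 1 `NC(=O)c1ccc2[nH]c(-c3ccc(OCCC4CCN(Cc5ccccc5)CC4)cc3)nc2c1` gives 5000 nM
Compound 2 `COc1ccc(CN2CCC(CCOc3ccc(-c4nc5cc(C(N)=O)ccc5[nH]4)cc3)CC2)cc1` gives < 1000 nM (a limit)

In this assay, going by these compounds, compound 2 has no number, only the limit < 1000 nM (and so its exact place remains open). Compound 3 `NC(=O)c1ccc2[nH]c(-c3ccc(OCCC4CCN(Cc5ccc(Cl)cc5)CC4)cc3)nc2c1` differs from compound 2 by one change (chloro in place of methoxy on an aromatic carbon): chloro in place of methoxy on an aromatic carbon, turning 4-methoxybenzyl into 4-chlorobenzyl. Within the data shown here, only one measured step bears on this change. Methoxy in place of hydrogen on an aromatic carbon gave an at least 5.0-fold lower number from compound 1 to compound 2 (0.69 log units; beyond the scatter) (the sole evidence at this place). Among the measured compounds shown here, no step involving chloro has been measured, so no firm direction can be drawn, and no change beyond the scatter is expected in this assay here. The expected step is a step that the limit leaves unreadable from compound 2 to compound 3 (an estimate). The expected value for compound 3 is 800 nM (estimated range 250 nM to 2500 nM).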

Compound 3, solubility: 2000 nM
Estimate against measurement, compound 3: 2.5-fold (0.40 log units) below, within the range that was stated.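

In this assay, chloro in place of hydrogen on the benzyl ring gives a 2.5-fold lower number from compound 1 to compound 3 (0.40 log units; beyond the scatter), so a second substituent at this position, after methoxy, also stands on the low side of the unsubstituted compound 1, this time with a readable number. Chloro in place of methoxy gives an at least 2.0-fold higher number from compound 2 to compound 3 (0.30 log units; that floor lies within the scatter), and as that floor lies within the scatter, this step does not yet separate the two groups. The step stays a floor because compound 2 carries only a limit: the limit of < 1000 nM in this assay, at which 1 of the 3 values shown sits.

Going by these compounds, how far chloro and methoxy truly differ here therefore remains open. So does the question of whether any group at this position falls short of hydrogen, since an amine or a carboxylic acid in the same place might behave quite differently from chloro and methoxy.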